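Replacing 4-bromophenyl with 2-methoxyphenyl on the shared core

The source may report more compounds than this note shows. Statements on the series, on what has been measured and on what is new or still open speak of the compounds shown alone.

Among the compounds with values here, compound 2 `Brc1ccc(-c2cn3ccnc3c(-c3ccc4ncn(C5CCCCC5)c4c3)n2)cc1` stands highest of the two compounds measured so far in a functional assay on SR cells (Homo sapiens) for inhibition, read by sulforhodamine B assay, with a stated time of 48 h, tested at 10 uM (a higher number here means more inhibition at the concentration tested (going by the name of the read-out), a lower number less inhibition), where compound 2 gives 60.7%. Within the data shown here, compound 1 `O=Cc1ccc(-c2cn3ccnc3c(-c3ccc4ncn(C5CCCCC5)c4c3)n2)cc1` gives 47.5% in this assay, and the only measured step, a number 13.2 percentage points higher from compound 1 to compound 2 (beyond the scatter), is a bromo in place of formyl on an aromatic carbon. Compound 3 `COc1ccccc1-c1cn2ccnc2c(-c2ccc3ncn(C4CCCCC4)c3c2)n1` carries 2-methoxyphenyl in place of 4-bromophenyl on an aromatic carbon. Among the measured compounds shown here, no measured step bears directly on this change; the one step known was modest. The estimate for compound 3 is therefore a modest loss, a number 10.7 percentage points lower from compound 2 to compound 3 (beyond the scatter), giving an expected value of 50% within a range from 30% to 70%.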

Compound 3, a percentage reported as inhibition, at one concentration (the size of the read-out at that concentration, not a potency): 26.3%
For compound 3 the middle estimate is 23.7 percentage points above the measured one; the whole stated range lies above it.
By their numbers in this assay, from the lowest: compound 3; then compound 1; then compound 2.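

In this assay, within the data shown here, the earlier compounds showed only a change of group on the phenyl ring, whereas this change also alters the group's place, and the response is larger: a number 34.4 percentage points lower from compound 2 to compound 3 (beyond the scatter), and a number 21.2 percentage points lower from compound 1 to compound 3 (beyond the scatter). Thus 2-methoxyphenyl reads below both 4-bromophenyl and 4-formylphenyl. Nothing available explains this drop. The compounds shown do not separate the effect of the methoxy group from that of its place on the ring, as 4-methoxyphenyl would. As far as these compounds go, how an amine or a carboxylic acid on this ring would read also stays open.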